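From 3-hydroxyphenyl to 2-methylphenyl: notes on compound 4

The source may hold more compounds than are shown below. What is called first, only, known or untested is meant among the compounds shown, and "the series" means these compounds.

Compound 1 `Fc1cccc(-c2nc(Nc3cccc(Cl)c3)c3cc(F)ccc3n2)c1` gives > 50000 nM
Compound 2 `Oc1ccc(Nc2nc(-c3cccc(F)c3)nc3ccc(F)cc23)cc1` gives > 50000 nM
Compound 3 `Oc1cccc(Nc2nc(-c3cccc(F)c3)nc3ccc(F)cc23)c1` gives > 50000 nM

All three values come from a functional assay on MDA-MB-231 cells (Homo sapiens) for cytotoxicity, read by MTT assay, with a stated time of 48 h (a lower number here means a stronger inhibitor, a higher number a weaker inhibitor), and each is a limit of the assay, not a number. Compound 3 stands with the other two at the limit of > 50000 nM in this assay, at which 3 of the 3 values shown sit, so no order can be read among them.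

Compound 4 `Cc1ccccc1Nc1nc(-c2cccc(F)c2)nc2ccc(F)cc12` carries 2-methylphenyl in place of 3-hydroxyphenyl on a nitrogen on an aromatic ring, and the counted difference is 2-methylphenyl in place of 3-hydroxyphenyl on a nitrogen on an aromatic ring. The measured steps that bear on this change are a step that the two limits leave unreadable from compound 1 to compound 3, a step that the two limits leave unreadable from compound 2 to compound 3 and a step that the two limits leave unreadable from compound 1 to compound 2. None of them has a readable size, and none of these three compounds gives a number. No step beyond the scatter is therefore expected in this assay, and no direction can be assigned. The estimated outcome is a number no higher from compound 3 to compound 4 (the limit leaves the size open). Compound 4 is expected at 50000 nM, with an estimated range from 20000 nM to 100000 nM, and the assay will probably report only a limit.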

Compound 4, half-maximal inhibitory concentration: > 50000 nM
Compound 4 was reported as a limit (the forecaster's own chance of this, stated with the estimate: 80%); the middle value sits exactly at the limit.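

No step can be read between compound 4 and compounds 1, 2 or 3 in this assay, because each gives only a limit: the limit of > 50000 nM in this assay, at which 4 of the 4 values shown sit.

The compounds shown leave open whether any group on the nitrogen, 2-methylphenyl included, changes the true value, and which change to the shared core would give a readable number.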